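Swapping benzofuranyl for phenyl on two nucleoside cores

A few compounds are considered here, and "the series" means these few. Any claim that something is new, unique, unknown or untested is made for them only; others in the source may bear on it.

Compound 3 `Cc1nc(N)c2c(-c3cc4ccccc4o3)cn([C@@H]3O[C@H](CO)[C@@H](O)[C@H]3O)c2n1` carries a 1-benzofuran-2-yl group, and in a functional assay on K562 cells (Homo sapiens), read by MTT assay, with a stated time of 72 h (a lower number here means a stronger inhibitor, a higher number a weaker inhibitor), compound 3 gives 15700 nM. Compound 1 `Cc1nc(N)c2c(-c3ccccc3)cn([C@@H]3O[C@H](CO)[C@@H](O)[C@H]3O)c2n1` differs from it by phenyl in place of 1-benzofuran-2-yl on an aromatic carbon. In this assay compound 1 gives only a limit, > 20000 nM. That change therefore produced an at least 1.2-fold higher number from compound 3 to compound 1 (0.10 log units; that floor lies within the scatter), with the floor set by the limit of > 20000 nM in this assay, at which 2 of the 3 values shown sit. Compound 2 `O=c1[nH]cnc2c1c(-c1cc3ccccc3o1)cn2[C@@H]1O[C@H](CO)[C@@H](O)[C@H]1O` bears the same 1-benzofuran-2-yl group on a different core; the difference between the two cores is not broken down here. In this assay compound 2 gives a limit, > 20000 nM. Compound 4 `O=c1[nH]cnc2c1c(-c1ccccc1)cn2[C@@H]1O[C@H](CO)[C@@H](O)[C@H]1O` stands to compound 2 as phenyl in place of 1-benzofuran-2-yl on an aromatic carbon, the same change as that between compound 3 and compound 1, made at a place described in identical words. Because the earlier step was an at least 1.2-fold higher number from compound 3 to compound 1 (0.10 log units; that floor lies within the scatter) and the starting point already sits at a limit, compound 4 is expected to remain at or beyond that limit, an estimated step that the limit leaves unreadable from compound 2 to compound 4 in this assay. Compound 4 is thus estimated at 40000 nM, expected to fall between 20000 nM and 120000 nM.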

Compound 4, half-maximal inhibitory concentration: > 20000 nM
Compound 4 was reported as a limit (the forecaster's own chance of this, stated with the estimate: 90%); the middle value is on the limit's open side.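

In this assay compound 4 gives > 20000 nM, which is a limit. No step can be read from compound 2 to compound 4, because both sit at the same limit: the limit of > 20000 nM in this assay, at which 3 of the 4 values shown sit. The compounds shown leave open whether phenyl in place of 1-benzofuran-2-yl changes anything on the core of compound 2.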